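The compounds below may be only part of what the source reports. "The series", "measured", "known", "first", "only" and "open" are said of these compounds alone.

Measured so far:
- compound 2, `CCCCCC(C#N)O[Si](C)(C)C`: 314000 nM
- compound 1, `C[Si](C)(C)OC(C#N)C1CCC1`: > 1000000 nM

In an assay on isolated protein for inhibition of Phenylethanolamine N-methyltransferase (Bos taurus) (on this read-out higher numbers stand for weaker inhibition and lower numbers for stronger inhibition), compound 2 gives the only actual number among the two results shown. For compound 1 the assay reports only a limit, (the limit of > 1000000 nM in this assay, at which 1 of the 2 values shown sits). Among the compounds with values here, no step between two measured compounds is available here.

Compound 3, `CC(C)CC(C#N)O[Si](C)(C)C`, differs from compound 2 by isopropyl in place of butyl on a saturated chain carbon, two bonds along the chain from an oxygen on an unsaturated carbon and a triple-bonded carbon. Without a measured step to lean on, the change from compound 2 to compound 3 is expected to be small, possibly a modest loss and not clearly beyond the scatter. Compound 3 is therefore estimated at 400000 nM, within 150000 nM to 1200000 nM. That estimate means an expected step of a 1.3-fold higher number from compound 2 to compound 3 (0.11 log units; within the scatter).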

Compound 3, half-maximal inhibitory concentration: 1000000 nM
The estimate for compound 3 lay 2.5-fold (0.40 log units) below the measured number, and the stated range covers the measured number.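

In this assay, isopropyl in place of butyl on a saturated chain carbon, two bonds along the chain from an oxygen on an unsaturated carbon and a triple-bonded carbon, gives a 3.2-fold higher number from compound 2 to compound 3 (0.50 log units; beyond the scatter). The group at this position does matter, and compound 2 is the stronger of the pair. The change both removes one carbon and introduces a branch, and this single pair cannot separate those two differences. Isobutyl in place of cyclobutyl on a saturated chain carbon bound to an oxygen and a triple-bonded carbon gives a number no higher from compound 1 to compound 3 (the limit leaves the size open). The size of this step cannot be read, because compound 1 has only a limit: the limit of > 1000000 nM in this assay, at which 1 of the 3 values shown sits. On these data alone, it remains open whether a longer chain, or an amine in place of butyl, would give a lower number.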